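The source may hold more compounds than are shown below. What is called first, only, known or untested is meant among the compounds shown, and "the series" means these compounds.

Compound 1 `N=C(N)NCCNc1cc(N2CCc3ccccc3C2)nc2ccccc12`: in an ADME assay on HEp-2 cells (Homo sapiens) for cytotoxicity, read by CCK-8 assay, with a stated time of 5 days (a lower number here means that less compound is tolerated, a higher number that more compound is tolerated), compound 1 gives > 100000 nM, which is a limit of the assay and not a number.
Compound 2 `Cc1ccc2nc(N3CCCc4ccc(F)cc4C3)cc(NC(C)(C)CN)c2c1`: in this assay compound 2 gives 25000 nM.

For the measured compounds named here, compound 2 therefore holds the only plain number among the two measured compounds; the other entry sits at the limit of > 100000 nM in this assay, at which 1 of the 2 values shown sits, so nothing can be said about how far apart the two compounds really are. Going by the values given here, no two measured compounds differ in a single place, so no measured step sets a scale for what a small change does here.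

Compound 3 `Cc1ccc2nc(N3CCCc4ccc(F)cc4C3)cc(NCCO)c2c1` is the compound still to be measured. It differs from compound 2 by 2-hydroxyethyl in place of 1-(aminomethyl)-1-methylethyl on a nitrogen on an aromatic ring. Both groups that leave and enter carry one hydrogen-bond donor and one acceptor, but the group entering is smaller and has no nitrogen.

Among the compounds with values here, with no measured step to lean on, the expected step is a 2.0-fold higher number from compound 2 to compound 3 (0.30 log units; within the scatter), a move toward more compound being tolerated, of a size that may not clear the usual scatter. Compound 3 is estimated at 50000 nM, with a range from 15000 nM to 150000 nM.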

Compound 3, half-maximal cytotoxic concentration: > 100000 nM
Compound 3 was reported as a limit (the forecaster's own chance of this, stated with the estimate: 35%); middle value at least 2.0-fold (0.30 log units) away from the limit.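

In this assay the entry for compound 3, > 100000 nM, is a limit of the assay and not a number. For the compounds shown here, the change of 1-(aminomethyl)-1-methylethyl to 2-hydroxyethyl on a nitrogen on an aromatic ring gives an at least 4.0-fold higher number from compound 2 to compound 3 (0.60 log units; beyond the scatter), the first step in this set that changes one place only, and it shows that this group alone can shift how much compound the cells tolerate, by more than the usual scatter. On these data alone, the printed step is only a lower bound, and the true size stays unknown, as the reading stops at the same limit as another entry in this small set: the limit of > 100000 nM in this assay, at which 2 of the 3 values shown sit.

This single change swaps nitrogen for oxygen and also makes the group smaller, so the compounds shown cannot tell which of these two differences goes with the higher number. A 2-aminoethyl group on the same nitrogen would keep the amine in a smaller group, and a longer chain such as 3-hydroxypropyl would keep the alcohol in a larger one, so each would help to pull the two differences apart.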